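A Fluorine Added to Compound 3

A few compounds are considered here, and "the series" means these few. Any claim that something is new, unique, unknown or untested is made for them only; others in the source may bear on it.

Compound 3 `O=C(COc1ccc(-c2ccccc2)cc1)Cn1nnc2ccccc21` gives the lowest number of the three compounds tested in an assay on microsomes from brain for inhibition of Fatty-acid amide hydrolase 1 (Rattus norvegicus), read by fluorescence and HPLC, with a stated time of 60 min (a lower number here means a stronger inhibitor, a higher number a weaker inhibitor), at 12 nM. Compound 2 `CCCCCCCCc1ccc(OCC(=O)Cn2cnnn2)cc1` comes nearest with 39 nM, and compound 1 `CCCCCCCCc1ccc(OCC(=O)Cn2cnc3ccccc32)cc1` lies furthest off at 480 nM. Going by the values given here, the one step measured between neighbours, a 12-fold lower number from compound 1 to compound 2 (1.09 log units; beyond the scatter), concerns a different part of the molecule. Compound 4 `O=C(COc1ccc(-c2ccc(F)cc2)cc1)Cn1nnc2ccccc21` differs from compound 3 only by fluoro in place of hydrogen on an aromatic carbon. Among the compounds with values here, no measured step bears on this change, and the exchange of phenyl for 4-fluorophenyl has no precedent among the three compounds, so no shift beyond the scatter is expected. Compound 4 is therefore estimated at 12 nM. For compound 4 the expected range runs from 5 nM to 30 nM. The expected step is no change at the digits printed from compound 3 to compound 4 (within the scatter).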

Compound 4, half-maximal inhibitory concentration: 12 nM
Compound 4: the middle estimate sits on the measured number at the digits printed, and the stated range covers the measured number.
By their numbers in this assay, from the lowest: compounds 3 and 4 (each within the scatter of the next); then compound 2; then compound 1.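

In this assay, going by these compounds alone, the step for fluoro in place of hydrogen on an aromatic carbon, para to a large group, reads no change at the digits printed from compound 3 to compound 4 (within the scatter) and is the only measured step at this position, since the earlier compounds offered none. At this position, then, the exchange of phenyl for 4-fluorophenyl leaves the number within the scatter. The compounds shown leave open whether a chloro, methoxy, trifluoromethyl or carboxylic acid group in the same place would also leave the number unmoved. No measured evidence bears on why this fluoro exchange gives this result.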